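A few compounds are considered here, and "the series" means these few. Any claim that something is new, unique, unknown or untested is made for them only; others in the source may bear on it.

Compound 1, `O=C1C(COCCCl)=CS(=O)(=O)c2ccccc21`, gives 98.1% in a functional assay on the whole organism for inhibition, with Mus musculus as the target, at a dose of 10 mg/kg; a higher number here means more inhibition at the dose given (going by the name of the read-out), a lower number less inhibition. Compound 2, `CCC(=O)OCC1=CS(=O)(=O)c2ccccc2C1=O`, gives 99.5% in this assay. Among the measured compounds shown here, the only measured step, a number 1.4 percentage points higher from compound 1 to compound 2 (within the scatter), exchanged one group for another on the oxygen and stayed within the scatter, so compound 2 and compound 1 cannot be told apart on these two numbers; both sit near the top of the percentage scale. Compound 3, `O=C1C(CBr)=CS(=O)(=O)c2ccccc21`, differs from compound 2 by bromo in place of propanoyloxy on a saturated chain carbon bound to a double-bonded ring carbon. For the measured compounds named here, no measured step covers this change: the one step measured kept an oxygen-bearing group on that saturated carbon, whereas here the oxygen leaves together with its group and bromo enters. The step this estimate means, a number 9.5 percentage points lower from compound 2 to compound 3 (within the scatter), is expected to be small or within the scatter, with little room to rise. Compound 3 is therefore estimated at 90%, within a range from 65% to 100%.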

Compound 3, a percentage reported as inhibition, in the whole organism at one dose (the size of the read-out at that dose, not a potency): 92.8%
Compound 3: middle estimate off by 2.8 percentage points, on the low side, and the stated range covers the measured number.
By their numbers in this assay, from the lowest: compounds 3, 1 and 2 (each within the scatter of the next).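

Among the compounds shown here, compound 3 is the first compound here with no oxygen attached to the saturated chain carbon, so this position has now been tested with more than a change of the group on that oxygen. In this assay putting bromo in place of propanoyloxy gives a number 6.7 percentage points lower from compound 2 to compound 3 (within the scatter) and putting bromo in place of 2-chloroethoxy gives a number 5.3 percentage points lower from compound 1 to compound 3 (within the scatter) at this same position. Among these three compounds, then, an oxygen on this carbon is not needed for a high reading at this dose, though nothing available explains this result.

From the compounds shown here alone, whether an amine or a carboxylic acid on this carbon would also give a high reading remains open. With all three numbers close to the top of the percentage scale at a single dose, any real differences in potency among these compounds also remain hidden.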